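The source may report more compounds than this note shows. Statements on the series, on what has been measured and on what is new or still open speak of the compounds shown alone.

Compound 1 `Fc1ccc(OC[C@@H]2CC[C@H]3CN(c4ncccn4)CCN3C2)cc1` gives 2.8 nM in an assay on CHO cells for binding affinity to D(4) dopamine receptor (Homo sapiens); a lower number here means a stronger inhibitor, a higher number a weaker inhibitor; compound 2 `COC(=O)c1ccc(OC[C@@H]2CC[C@H]3CN(c4ncccn4)CCN3C2)cc1` gives 127 nM.

Among the two measured compounds, compound 2 stands at the higher number, that is the weaker binder of the pair, and the only measured step, a 45-fold higher number from compound 1 to compound 2 (1.66 log units; beyond the scatter), is a large one. Compound 3 `CC(=O)Nc1ccc(OC[C@@H]2CC[C@H]3CN(c4ncccn4)CCN3C2)cc1` differs from compound 2 in one place: acetamido in place of methoxycarbonyl on an aromatic carbon. Among the compounds with values here, no measured step swaps one group of this size for another at that position; the single step known replaced a small group by a larger one and raised the number strongly. Since the group that enters resembles the group that leaves in size, a step of only modest size is expected from compound 2 to compound 3, a 1.6-fold lower number from compound 2 to compound 3 (0.20 log units; within the scatter), without a clear direction. Compound 3 is therefore estimated at 80 nM, within a range from 20 nM to 400 nM.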

Compound 3, inhibition constant: 316 nM
For compound 3 the middle estimate is 4.0-fold (0.60 log units) below the measured one; measured number inside the range.
By their numbers in this assay, from the lowest: compound 1; then compound 2; then compound 3.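

Methoxycarbonyl and acetamido each have 4 heavy atoms, yet the change between them still gives a step beyond the scatter (a 2.5-fold higher number from compound 2 to compound 3 (0.40 log units; beyond the scatter)) in this assay. Group size alone therefore does not set the number at this position, on an aromatic carbon para to a large group. The step (a 110-fold higher number from compound 1 to compound 3 (2.05 log units; beyond the scatter)) also shows that the high number is not confined to methoxycarbonyl: both larger groups sit well above fluoro, with acetamido the higher of the two.

As far as these compounds go, it remains open whether other small groups, such as chloro or methoxy, would stay close to fluoro, and where an amine or a carboxylic acid would fall at this position. Nothing available here explains the difference between these groups.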